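This account rests on a few compounds, and the source may have more. Where it says the series, first, only, none or still open, it means among the compounds named here.

Of the compounds shown here, three have been measured so far in a functional assay on CHO-K1 cells for antagonist activity at transient receptor potential cation channel subfamily V member 1 (Homo sapiens), read by FLIPR; on this read-out higher numbers stand for weaker inhibition and lower numbers for stronger inhibition. Compound 2 `CC(C(=O)NCc1ccc(C(F)(F)F)nc1Nc1ccc(F)cc1)c1ccc(NS(C)(=O)=O)c(F)c1` gives 39.2 nM, the highest of the three numbers. Compound 1 `CC(C(=O)NCc1ccc(C(F)(F)F)nc1NCC1CCN(C(=O)OC(C)(C)C)CC1)c1ccc(NS(C)(=O)=O)c(F)c1` gives 19.3 nM, a gap from compound 2 that lies beyond the usual scatter. Compound 3 `CC1CCCN1c1nc(C(F)(F)F)ccc1CNC(=O)[C@@H](C)c1ccc(NS(C)(=O)=O)c(F)c1` gives 0.3 nM, far below both. Compound 2 and compound 3 share the same core and differ only in the group attached to it: compound 3 carries a ring-bound amine with no hydrogen-bond donor there, while compound 2 carries an aromatic amine that does have one.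

Compound 4 `CC(C(=O)NCc1ccc(C(F)(F)F)nc1N1CC=CCC1)c1ccc(NS(C)(=O)=O)c(F)c1` has not yet been measured. It differs from compound 2 in one place: a group of 6 heavy atoms (5 carbon, 1 nitrogen; one six-membered non-aromatic ring with 1 hetero atom) in place of a group of 8 heavy atoms (6 carbon, 1 nitrogen, 1 fluorine; one six-membered aromatic ring of carbon only), on an aromatic carbon. As in compound 3, the nitrogen that enters sits in a ring and brings 0 hydrogen-bond donors. Because compound 3 reaches 0.3 nM with that kind of nitrogen sitting in a ring, the step from compound 2 to compound 4 is expected to lower the number beyond the scatter, a 13-fold lower number from compound 2 to compound 4 (1.12 log units; beyond the scatter). Compound 4 is therefore estimated at 3 nM, with a likely range from 0.5 nM to 20 nM.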

Compound 4, inhibition constant: 0.3 nM
Estimate against measurement, compound 4: 10-fold (1.00 log units) above; the measured number lies below the stated range.
By their numbers in this assay, from the lowest: compounds 3 and 4 (each within the scatter of the next); then compound 1; then compound 2.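

For the compounds shown here, this is the first step in the set that changes only one place, the aromatic carbon next to the ring nitrogen, and the number responds strongly there: replacing (4-fluorophenyl)amino with the six-membered non-aromatic ring gives a 130-fold lower number from compound 2 to compound 4 (2.12 log units; beyond the scatter) in this assay. This position therefore does not merely tolerate a ring-bound nitrogen with no hydrogen-bond donor, since the change brings a large gain in inhibition. Going by these compounds alone, the single step changes several things at once, including the aromatic ring, the donor count and the double bond, and nothing available shows which of these matters or explains the size of the step.

Going by these compounds, it remains open whether a saturated piperidine ring would match compound 4, which would show what the double bond contributes. A 4-fluorophenyl ring on a methylated nitrogen would separate the loss of the donor from the loss of the aromatic ring.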